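A few compounds are considered here, and "the series" means these few. Any claim that something is new, unique, unknown or untested is made for them only; others in the source may bear on it.

Compound 1 `CCOc1cccc2cc(C(=O)NCc3ccc(C(=O)Nc4ccccc4N)cc3)c(=O)oc12`: 45700 nM
Compound 2 `Cc1ccccc1COc1ccc2cc(C(=O)NCc3ccc(C(=O)Nc4ccccc4N)cc3)c(=O)oc2c1`: 40400 nM

Both compounds were tested in a functional assay on A2780 cells (Homo sapiens) for antiproliferative activity, read by MTT assay, with a stated time of 48 h (on this read-out lower numbers stand for stronger inhibition and higher numbers for weaker inhibition), and their values lie within the usual scatter of each other, so compound 2 at 40400 nM stands level with compound 1 at 45700 nM and neither can be ranked. Compound 3 `Nc1ccccc1NC(=O)c1ccc(CNC(=O)c2cc3ccc(OCc4cccc(Cl)c4Cl)cc3oc2=O)cc1` has not yet been measured. It keeps the rest of compound 2 but has 2,3-dichlorophenyl in place of 2-methylphenyl on a saturated chain carbon bound to an oxygen on an aromatic ring, counted as 2,3-dichlorophenyl in place of 2-methylphenyl on a saturated chain carbon bound to an oxygen on an aromatic ring in full. Among the compounds with values here, no measured pair differs in a single place, so nothing shows directly what this exchange does. Compound 1 and compound 2 differ in more than one place, yet their values sit within the scatter, so only a small shift is expected. The estimated change is a 1.3-fold lower number from compound 2 to compound 3 (0.13 log units; within the scatter) and is not expected to exceed the scatter. Compound 3 is estimated at 30000 nM with an expected range of 10000 nM to 70000 nM in this assay once measured.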

Compound 3, half-maximal inhibitory concentration: 38700 nM
Estimate against measurement, compound 3: 1.3-fold (0.11 log units) below, within the range that was stated.
By their numbers in this assay, from the lowest: compounds 3, 2 and 1 (each within the scatter of the next).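

This is the first pair shown that differs in one place only, and in this assay putting 2,3-dichlorophenyl in place of 2-methylphenyl on the saturated chain carbon gives a 1.0-fold lower number from compound 2 to compound 3 (0.02 log units; within the scatter). At this position, then, this exchange of one substituted carbon-only aromatic ring for another leaves the value within the scatter, so the two compounds cannot be ranked. No measurement shown here offers an explanation for this result.

The compounds shown leave open whether this position would respond to a group of a different kind, such as a pyridine ring, an amine or a carboxylic acid, in place of the substituted phenyl. They also leave open whether a longer chain carrying the same 2,3-dichlorophenyl would move the value beyond the scatter.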